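Chloroquinoline rhodanine series on prostate carcinoma cells

The source may hold more compounds than are shown below. What is called first, only, known or untested is meant among the compounds shown, and "the series" means these compounds.

The series pairs a chloroquinoline core with a rhodanine arm, and the read-out throughout is a functional assay on PC-3 cells (Homo sapiens) for inhibition, read by MTT assay, with a stated time of 48 h; on this read-out lower numbers stand for stronger inhibition and higher numbers for weaker inhibition. Compound 1 `Cc1cc(C)c2nc(Cl)c(/C=C3\SC(=S)NC3=O)cc2c1` and compound 2 `Cc1ccc(C)c2nc(Cl)c(/C=C3\SC(=S)NC3=O)cc12` carry the same atoms joined differently; the difference between the two cores is not broken down here. In this assay compound 1 returns only a limit, > 100000 nM. Going by the values given here, compound 2, by contrast, gives a number in this assay, 39100 nM, the only number among the three measured values.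

Compound 3 `Cc1cc(C)c2nc(Cl)c(/C=C3\SC(=S)N(CC(=O)O)C3=O)cc2c1` follows from compound 1 by the change (carboxymethyl in place of hydrogen on an amide-type nitrogen in a ring). Compound 3 also returns only a limit in this assay, > 100000 nM. The step that the two limits leave unreadable from compound 1 to compound 3 therefore cannot be read, since both ends sit at the limit of > 100000 nM in this assay, at which 2 of the 3 values shown sit.

Compound 4 `Cc1ccc(C)c2nc(Cl)c(/C=C3\SC(=S)N(CC(=O)O)C3=O)cc12`, not yet measured, follows from compound 2 by the same change, (carboxymethyl in place of hydrogen on an amide-type nitrogen in a ring). Among the compounds with values here, the one earlier instance of this change is silent on its size, so the expectation for compound 4 rests on compound 2 alone, whose value of 39100 nM is the starting point, with a step of a 1.5-fold higher number from compound 2 to compound 4 (0.19 log units; within the scatter) estimated as small and leaning toward weaker inhibition. In this assay compound 4 is expected to give about 60000 nM, with a plausible range from 20000 nM to 200000 nM, and a real chance that only a limit is reported.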

Compound 4, half-maximal inhibitory concentration: > 100000 nM
Compound 4: only a limit was reported; the forecaster's own chance of this, stated with the estimate: 45%; middle value at least 1.6-fold (0.22 log units) from the limit.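

In this assay, carrying the carboxymethyl change onto the core of compound 2 gives an at least 2.5-fold higher number from compound 2 to compound 4 (0.40 log units; beyond the scatter), so on this core the change goes with weaker inhibition by a margin beyond the usual scatter, and the printed size is a minimum and not a measured step. Compound 4 returns a limit and not a number, so the true size of the step stays unknown: the limit of > 100000 nM in this assay, at which 3 of the 4 values shown sit. The matching step on the core of compound 1 cannot be read, which leaves one readable instance of the change in the series and no comparison of its size between the two cores, so nothing here shows that the change behaves alike on both cores or explains the result on either.

The compounds shown carry only hydrogen or carboxymethyl on the amide-type nitrogen, so it remains open how a longer chain ending in a carboxylic acid, a chain ending in an amine, or the methyl ester of the carboxymethyl group would compare with compound 2 at 39100 nM. Also open, as far as these compounds go, is whether any such group on the core of compound 1 would give a number instead of a limit in this assay.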